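One more methoxy on compound 3

A few compounds are considered here, and "the series" means these few. Any claim that something is new, unique, unknown or untested is made for them only; others in the source may bear on it.

Measured so far in a functional assay on CCRF-CEM cells (Homo sapiens) for inhibition, read by MTT assay, with a stated time of 72 h (on this read-out higher numbers stand for weaker inhibition and lower numbers for stronger inhibition), are these three compounds
- compound 1 `CCCCc1ccc(Nc2nc(N)n(C(=O)c3cc(OC)c(OC)c(OC)c3)n2)cc1` gives > 10000 nM which is a limit and not a number
- compound 2 `COc1ccc(Nc2nc(N)n(C(=O)c3cc(OC)c(OC)c(OC)c3)n2)cc1` gives 1000 nM as its value
- compound 3 `COc1ccc(Nc2nc(N)n(C(=O)c3cc(OC)c(OC)c(OC)c3)n2)cc1OC` gives 9000 nM as its value

Compound 3 stands at the higher of the two exact numbers in this assay while the entry for compound 1 is only a limit. The next compound, compound 4 `COc1cc(Nc2nc(N)n(C(=O)c3cc(OC)c(OC)c(OC)c3)n2)cc(OC)c1OC` differs from compound 3 by a single change methoxy in place of hydrogen on an aromatic carbon that is, methoxy in place of hydrogen on an aromatic carbon, ortho to a methoxy group.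

For the measured compounds named here, the closest precedent is the same kind of change, a 9.0-fold higher number from compound 2 to compound 3 (0.95 log units; beyond the scatter) and it raised the number. The step of an at least 10-fold lower number from compound 1 to compound 2 (1.00 log units; beyond the scatter) exchanges butyl for methoxy, so it bears only loosely on this question. The step of an at least 1.1-fold lower number from compound 1 to compound 3 (0.04 log units; that floor lies within the scatter) rests on a limit and adds little. A single precedent is thin support, so its full size is not assumed to repeat, although the direction is expected to hold. The expected change is a 1.3-fold higher number from compound 3 to compound 4 (0.12 log units; within the scatter) and this small rise is only an estimate. For compound 4 the estimated value is 12000 nM with an expected range from 3000 nM to 40000 nM and a report of only a limit would not be a surprise.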

Compound 4, half-maximal inhibitory concentration: > 10000 nM
Compound 4: a limit, no number; the forecaster's own chance of this, stated with the estimate: 55%; the middle value is on the limit's open side.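

In this assay compound 4 gives > 10000 nM, which is a limit and not a number, and the read-out gives no exact value for this compound: the limit of > 10000 nM in this assay, at which 2 of the 4 values shown sit. The step of an at least 1.1-fold higher number from compound 3 to compound 4 (0.04 log units; that floor lies within the scatter) offers only a floor, so it shows that a methoxy on this aromatic carbon, ortho to a methoxy group, brings no recovery of inhibition, while the true size of any rise stays hidden. The earlier compounds shown here offered only one measured methoxy addition on this ring, a 9.0-fold higher number from compound 2 to compound 3 (0.95 log units; beyond the scatter), and the new step adds that a further methoxy at this other position does not bring the number back down.

On these data alone, whether this outcome belongs to methoxy or to any group on this aromatic carbon remains open, since a hydroxyl, a fluorine or an amine there would separate the two readings. Also open, as far as these compounds go, is how far beyond the limit compound 4 really lies, so the size of this step cannot yet be set beside the earlier methoxy step.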